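The source may report more compounds than this note shows. Statements on the series, on what has been measured and on what is new or still open speak of the compounds shown alone.

Compound 1 `CNC(=O)c1cc(C(=O)NC2CC2)cn(Cc2cccc(OC)c2)c1=O` gives 79 ug/mL in a physicochemical assay for solubility; on this read-out higher numbers stand for higher solubility and lower numbers for lower solubility.
Compound 2 `CNC(=O)c1cc(C(=O)NC2CC2)cn(Cc2cccc3cc[nH]c23)c1=O` gives >= 144 ug/mL in this assay; this is a limit of the assay and not a number.
Compound 3 `CNC(=O)c1cc(C(=O)NC2CC2)cn(Cc2ccc(OC)cc2)c1=O` is not yet measured in this assay.

Compound 2 stands at the limit of >= 144 ug/mL in this assay, at which 1 of the 2 values shown sits, so only a floor is known for it. The change to compound 3 is 4-methoxyphenyl in place of 1H-indol-7-yl on a saturated chain carbon bound to an aromatic nitrogen. Among the measured compounds shown here, the one measured step that bears on it is an at least 1.8-fold higher number from compound 1 to compound 2 (0.26 log units; that floor lies within the scatter), which runs the opposite way, from a methoxyphenyl to the indolyl, and its size is open-ended. Reversing it suggests a lower number for compound 3, of a size the limit does not fix. Compound 3 is expected at 80 ug/mL (40 ug/mL to 160 ug/mL), resting on an at least 1.8-fold higher number from compound 1 to compound 2 (0.26 log units; that floor lies within the scatter) read in reverse. A step of an at least 1.8-fold lower number from compound 2 to compound 3 (0.25 log units; that floor lies within the scatter) is expected.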

Compound 3, solubility: >= 143 ug/mL
Compound 3 gave a limit, no number (the forecaster's own chance of this, stated with the estimate: 25%); middle value at least 1.7-fold (0.25 log units) from the limit.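

In this assay compound 3 gives >= 143 ug/mL, a limit and not a number, so the limit is no longer reached by 1H-indol-7-yl alone on this saturated chain carbon. Setting 4-methoxyphenyl in place of 3-methoxyphenyl gives an at least 1.8-fold higher number from compound 1 to compound 3 (0.25 log units; that floor lies within the scatter). The step between compound 2 and compound 3 cannot be read; both values are limits.

Going by these compounds, the true values of compound 2 and compound 3 stay open, so the two groups cannot be ranked. Also open, on these data alone, is whether an amine or a carboxylic acid on this benzyl-type substituent would give a number rather than a limit.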